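The source may hold more compounds than are shown below. What is called first, only, known or untested is meant among the compounds shown, and "the series" means these compounds.

Compound 1 `CCCCCC(CCO)n1cnc2c(Cl)nc(Cl)nc21`: 6170 nM
Compound 2 `CCCCCCC(CCO)n1cnc2c(Cl)nc(Cl)nc21`: 12100 nM
Compound 3 `CCCCCCCCC(CCO)n1cnc2c(Cl)nc(F)nc21`: 24200 nM

In a functional assay on HCT-116 cells (Homo sapiens) for antiproliferative activity, read by MTT assay, with a stated time of 48 h (on this read-out higher numbers stand for weaker inhibition and lower numbers for stronger inhibition), compound 3 gives 24200 nM. That number lies within the scatter of the value of compound 2, 12100 nM. It is higher, beyond the scatter, than the value of compound 1, 6170 nM.

The next compound, compound 4 `CCCCCCCCC(CCO)n1cnc2c(Cl)nc(Cl)nc21`, has not yet been measured. It differs from compound 3 in one place: chloro in place of fluoro on an aromatic carbon. This is chloro in place of fluoro on an aromatic carbon, between two ring nitrogen atoms. Compound 1 and compound 2 also carry chloro on that carbon.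

For the measured compounds named here, only one measured step is available, a 2.0-fold higher number from compound 1 to compound 2 (0.29 log units; within the scatter). It is a methyl in place of hydrogen on a saturated chain carbon, and it stays within the scatter. Going by the values given here, that step does not touch the halogen, and no measured pair isolates chloro against fluoro, so the data give no size for this exchange. With compound 3 at 24200 nM as the anchor, no change beyond the scatter is expected in this assay, in either direction, and the range is kept wide. The expected step is a 1.2-fold lower number from compound 3 to compound 4 (0.08 log units; within the scatter). For compound 4 the estimated value is 20000 nM, with an expected range from 9000 nM to 45000 nM.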

Compound 4, half-maximal inhibitory concentration: 22200 nM
Estimate against measurement, compound 4: 1.1-fold (0.05 log units) below; the measured number falls inside the stated range.
By their numbers in this assay, from the lowest: compounds 1, 2, 4 and 3 (each within the scatter of the next, the first and the last beyond it).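

In this assay, chloro in place of fluoro on an aromatic carbon, between two ring nitrogen atoms, gives a 1.1-fold lower number from compound 3 to compound 4 (0.04 log units; within the scatter), so this first pair to isolate the exchange shows no difference between the two halogens at this position on the longest chain shown. With chloro held on that carbon, compound 4 also extends the chain series: a 1.8-fold higher number from compound 2 to compound 4 (0.26 log units; within the scatter) stays within the scatter, while the span across the series, a 3.6-fold higher number from compound 1 to compound 4 (0.56 log units; beyond the scatter), goes beyond it, the only chain step shown to do so and one that makes compound 1 clearly stronger than compound 4. Nothing in the available evidence accounts for either the matching halogens or the gap across the chain series.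

On these data alone, the halogen result rests on this single pair, so it remains open whether fluoro and chloro would also match on the shorter chains of compound 1 and compound 2. Also open, as far as these compounds go, are how an amine or bromo on that aromatic carbon would compare with chloro, and whether a longer chain would push the number higher still.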